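The compounds below may be only part of what the source reports. "The series", "measured", "known", "first", "only" and "open" are said of these compounds alone.

The measured compounds in a functional assay on Jurkat cells (Homo sapiens) for inhibition; on this read-out higher numbers stand for weaker inhibition and lower numbers for stronger inhibition:
Compound 1 `CC(C)[C@H](NC(=O)COc1cccc2ccccc12)C(=O)N[C@@H](CC(=O)O)C(=O)CSc1nnnn1-c1ccccc1`, which gives 153000 nM.
Compound 2 `CC(C)[C@H](NC(=O)COc1cccc2ccccc12)C(=O)N[C@@H](CC(=O)O)C(=O)CSc1nc2ccccc2s1`, for which only the limit > 200000 nM is reported.
Compound 3 `CC(C)[C@H](NC(=O)COc1cccc2ccccc12)C(=O)N[C@@H](CC(=O)O)C(=O)COc1cccc2cccnc12`, for which only the limit > 200000 nM is reported.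

Compound 3 thus stands at the limit of > 200000 nM in this assay, at which 2 of the 3 values shown sit. The steps of an at least 1.3-fold higher number from compound 1 to compound 3 (0.11 log units; that floor lies within the scatter) and a step that the two limits leave unreadable from compound 2 to compound 3 end at compound 3, but neither concerns the change that leads to compound 4 `CC(C)[C@H](NC(=O)COc1cccc2ccccc12)C(=O)N[C@@H](CC(=O)O)C(=O)COc1cncc2ccccc12`: isoquinolin-4-yl in place of quinolin-8-yl on an oxygen on a saturated carbon. Among the measured compounds shown here, no measured step bears on this swap of one bicyclic aromatic group for the other, so nothing in the data points to a move beyond the scatter in either direction in this assay . The expected step is a number no higher from compound 3 to compound 4 (the limit leaves the size open), essentially none. Compound 4 is estimated at 200000 nM, with a range from 80000 nM to 500000 nM, and most likely again only a limit.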

Compound 4, half-maximal inhibitory concentration: 166000 nM
For compound 4 the middle estimate is 1.2-fold (0.08 log units) above the measured one; low and high end bracket the measured number.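

In this assay, (isoquinolin-4-yl)oxy gives a number, but the change from quinolin-8-yl reads only as an at least 1.2-fold lower number from compound 3 to compound 4 (0.08 log units; that floor lies within the scatter), and the change from (1,3-benzothiazol-2-yl)sulfanyl only as an at least 1.2-fold lower number from compound 2 to compound 4 (0.08 log units; that floor lies within the scatter). The change from (1-phenyl-1H-tetrazol-5-yl)sulfanyl reads as a 1.1-fold higher number from compound 1 to compound 4 (0.04 log units; within the scatter), so these two groups cannot be told apart here. Compound 2 and compound 3 each remain a limit: the limit of > 200000 nM in this assay, at which 2 of the 4 values shown sit. The compounds shown leave open whether an amine on the isoquinolin-4-yl group would move the number beyond the scatter.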